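A few compounds are considered here, and "the series" means these few. Any claim that something is new, unique, unknown or untested is made for them only; others in the source may bear on it.

Measured in a functional assay on MGC-803 cells (Homo sapiens) for antiproliferative activity, read by CCK-8 assay, with a stated time of 72 h, tested at 2 uM; on this read-out lower numbers stand for a weaker effect and higher numbers for a stronger effect at the one concentration tested:
compound 1 `Nc1ccccc1NC(=O)c1ccc(CSC(=S)N2CCN(c3ccc(Cl)cc3)CC2)cc1` gives 15%
compound 2 `Nc1ccccc1NC(=O)c1ccc(CSC(=S)N2CCN(c3ccccc3F)CC2)cc1` gives 33.7%

Within the data shown here, compound 2 stands highest of the two numbers, the nearest being compound 1 with 15%; the single measured step, a number 18.7 percentage points higher from compound 1 to compound 2 (beyond the scatter), is modest yet beyond the scatter. Compound 3 `Nc1ccccc1NC(=O)c1ccc(CSC(=S)N2CCN(c3ccncc3)CC2)cc1` carries the change (pyridin-4-yl in place of 2-fluorophenyl on an amine nitrogen in a ring). Among the measured compounds shown here, no measured step touches pyridin-4-yl; the only one, a number 18.7 percentage points higher from compound 1 to compound 2 (beyond the scatter), shows that exchanging the group on the ring nitrogen shifts the read-out modestly, so a shift of similar size in this assay is expected, direction uncertain, with the lower side weighted because compound 2 already holds 33.7% as the top number. Compound 3 is expected to give 25% (range 8% to 42%), a step of a number 8.7 percentage points lower from compound 2 to compound 3 (within the scatter).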

Compound 3, a percentage reported as inhibition, at one concentration (the size of the read-out at that concentration, not a potency): 64.8%
The estimate for compound 3 lay 39.8 percentage points below the measured number, and the stated range ends below it.
By their numbers in this assay, from the lowest: compound 1; then compound 2; then compound 3.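

In this assay the group on the amine nitrogen of the ring can move the read-out much further than the earlier exchange showed: pyridin-4-yl in place of 2-fluorophenyl gives a number 31.1 percentage points higher from compound 2 to compound 3 (beyond the scatter), and in place of 4-chlorophenyl it gives a number 49.8 percentage points higher from compound 1 to compound 3 (beyond the scatter). Among these compounds, of the three compounds, compound 3, the only one whose group has a hetero atom in the aromatic ring and a hydrogen-bond acceptor, stands highest, with both steps beyond the scatter. Nothing available explains this gain. On these data alone, whether it depends on where the ring nitrogen sits remains open; pyridin-3-yl, pyridin-2-yl and unsubstituted phenyl at this place would address that.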